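Moving the Chlorine on the Urea Aryl Ring

A few compounds are considered here, and "the series" means these few. Any claim that something is new, unique, unknown or untested is made for them only; others in the source may bear on it.

Measured so far:
Compound 1 `CN(C)CCCNc1nc(-c2ccc(NC(=O)Nc3ccccc3Cl)cc2)nc2ccsc12` gives 690 nM in a functional assay on MKN-45 cells (Homo sapiens) for cytotoxicity, read by MTT assay, with a stated time of 72 h; on this read-out lower numbers stand for stronger inhibition and higher numbers for weaker inhibition.
Compound 2 `CCN(CC)CCCNc1nc(-c2ccc(NC(=O)Nc3ccc(Cl)cc3)cc2)nc2ccsc12` gives 180 nM in this assay.

Compound 2 holds the lower of the two numbers, and compound 1 sits above it by a gap beyond the usual scatter. Within the data shown here, these two compounds differ from each other in more than one place, so no single step between them can be read off. Compound 3 `CCN(CC)CCCNc1nc(-c2ccc(NC(=O)Nc3ccccc3Cl)cc2)nc2ccsc12` is compound 2 with one change only: 2-chlorophenyl in place of 4-chlorophenyl on an amide-type nitrogen. Compound 1 carries that same 2-chlorophenyl group, alongside a different amine group, and gives 690 nM. On that basis the change is expected to weaken the inhibition in this assay by a step of moderate size, a 2.5-fold higher number from compound 2 to compound 3 (0.40 log units; beyond the scatter), though the second difference between the two measured compounds leaves this uncertain. Compound 3 is therefore estimated at 450 nM, within a range from 180 nM to 1100 nM.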

Compound 3, half-maximal inhibitory concentration: 390 nM
Compound 3: middle estimate off by 1.2-fold (0.06 log units), on the high side; the measured number falls inside the stated range.
By their numbers in this assay, from the lowest: compound 2; then compounds 3 and 1 (each within the scatter of the next).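

Taken alone, 2-chlorophenyl in place of 4-chlorophenyl on an amide-type nitrogen gives a 2.2-fold higher number from compound 2 to compound 3 (0.34 log units; beyond the scatter) in this assay, so where the chlorine sits on this ring matters by itself, though the step is modest. With 2-chlorophenyl held fixed, diethylamino in place of dimethylamino gives a 1.8-fold lower number from compound 1 to compound 3 (0.25 log units; within the scatter), so that pair cannot be told apart in this assay. No measurement here explains why moving the chlorine changes the number.

As far as these compounds go, whether the chlorine move has a step of similar size with dimethylamino on the chain remains open. Also open, from the compounds shown here alone, is how an unsubstituted phenyl in place of 4-chlorophenyl, or morpholine in place of diethylamino, would compare.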